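Removal of the aryl methoxy group in the indole series

The source may hold more compounds than are shown below. What is called first, only, known or untested is meant among the compounds shown, and "the series" means these compounds.

Measured so far:
compound 1 `COc1ccc(-c2[nH]c3ccccc3c2/C=C(\C#N)S(=O)(=O)c2ccccc2)cc1` — 383 nM
compound 2 `COc1ccc(-c2[nH]c3ccc(OC)cc3c2/C=C(\C#N)S(=O)(=O)c2ccccc2)cc1` — 500 nM
compound 3 `O=C(/C(=C\c1c(-c2ccccc2)[nH]c2ccccc12)S(=O)(=O)c1ccccc1)c1ccccc1` — 15600 nM

In a functional assay on M14 cells (Homo sapiens) for inhibition, read by sulforhodamine B assay, with a stated time of 48 h (a lower number here means a stronger inhibitor of growth, a higher number a weaker inhibitor of growth), compound 2 gives the second highest of the three numbers. Compound 1 lies nearest, and the gap from compound 1 to compound 2 is a 1.3-fold higher number from compound 1 to compound 2 (0.12 log units; within the scatter), so the two cannot be told apart. Within the data shown here, compound 3 lies furthest, with a markedly higher number, but it differs from compound 2 in more than one place and no single step connects them.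

Compound 4 `COc1ccc2[nH]c(-c3ccccc3)c(/C=C(\C#N)S(=O)(=O)c3ccccc3)c2c1` is the next compound; it differs from compound 2 by hydrogen in place of methoxy on an aromatic carbon, which cut one bond further out reads 4-methoxyphenyl to phenyl. Among the measured compounds shown here, the only measured single step, the methoxy added on the core from compound 1 to compound 2, stayed within the scatter. For the measured compounds named here, that step touches a different ring, so it bears on the present change only loosely, and no direct precedent exists. The expectation for compound 4 is therefore a step of no change at the digits printed from compound 2 to compound 4 (within the scatter), with no change beyond the scatter. Compound 4 is estimated at 500 nM, within 200 nM to 1300 nM.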

Compound 4, concentration for 50% growth inhibition: 3700 nM
For compound 4 the middle estimate is 7.4-fold (0.87 log units) below the measured one; measured number above the stated range.
By their numbers in this assay, from the lowest: compounds 1 and 2 (each within the scatter of the next); then compound 4; then compound 3.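

In this assay, exchanging 4-methoxyphenyl for phenyl gives a clear loss of growth inhibition (a 7.4-fold higher number from compound 2 to compound 4 (0.87 log units; beyond the scatter)), whereas adding methoxy on the core left the number within the scatter (a 1.3-fold higher number from compound 1 to compound 2 (0.12 log units; within the scatter)). Methoxy therefore does not count equally at these two places: in this pair, the number is sensitive to the group on the aromatic carbon para to a large group, which the core step could not show. Nothing available here accounts for the size of this step.

On these data alone, it remains open whether the methoxy itself is the requirement, or whether another group at this place, such as ethoxy, hydroxy, fluorine or a dimethylamino group, would hold the number of compound 2. As far as these compounds go, it is also open whether the same change would cost as much on the core of compound 1, which lacks the core methoxy.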